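Swapping Dimethylphenyl for Fluorophenyl on a Shared Core

The compounds below may be only part of what the source reports. "The series", "measured", "known", "first", "only" and "open" are said of these compounds alone.

Of the compounds shown here, three sharing one core have been tested in an assay for inhibition of histone-lysine N-methyltransferase, H3 lysine-79 specific (Homo sapiens), with stated times of 15 min and 120 min, tested at 50 uM; a higher number here means more inhibition at the concentration tested (going by the name of the read-out), a lower number less inhibition. Compound 1 `Fc1cccc(-c2nn3c(Cc4ccccc4)nnc3s2)c1` gives 33%. Compound 2 `Brc1cccc(-c2nn3c(Cn4cnc5ccccc54)nnc3s2)c1` gives 62%. Compound 3 `Cc1ccc(-c2nn3c(Cn4cnc5ccccc54)nnc3s2)cc1C` gives 72%, the highest of the three numbers; the step of a number 10 percentage points higher from compound 2 to compound 3 (within the scatter) lies within the scatter, while compound 1 sits far lower, beyond the scatter.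

The next compound, compound 4 `Fc1cccc(-c2nn3c(Cn4cnc5ccccc54)nnc3s2)c1`, is compound 3 with one change: 3-fluorophenyl in place of 3,4-dimethylphenyl on an aromatic carbon.

For the measured compounds named here, only one measured step bears on this change, and only loosely: a number 10 percentage points higher from compound 2 to compound 3 (within the scatter), a step within the scatter that exchanged one halogen-bearing phenyl for the dimethylphenyl. Compound 1 also carries a 3-fluorophenyl group, yet it differs from compound 3 at a second place as well, so a single step cannot be read from the value compound 1 gives, 33%. A return to a small halogen on the phenyl ring is therefore expected to cost somewhat, with the step of a number 17 percentage points lower from compound 3 to compound 4 (beyond the scatter) estimated to fall near or just beyond the edge of the scatter. Compound 4 is expected to give about 55%, within a range of 35% to 75%.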

Compound 4, a percentage reported as inhibition, at one concentration (the size of the read-out at that concentration, not a potency): 57%
Estimate against measurement, compound 4: 2 percentage points below; low and high end bracket the measured number.
By their numbers in this assay, from the lowest: compound 1; then compounds 4, 2 and 3 (each within the scatter of the next, the first and the last beyond it).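

For the compounds shown here, the first step at this position to clear the scatter is a number 15 percentage points lower from compound 3 to compound 4 (beyond the scatter), so in this assay the group on this aromatic carbon can shift the read-out, though only modestly, when 3-fluorophenyl stands in place of 3,4-dimethylphenyl. The halogen swap gives a number 5 percentage points lower from compound 2 to compound 4 (within the scatter), which means fluoro and bromo on the phenyl ring cannot be told apart here, and compound 2 sits within the scatter of both compound 3 and compound 4, so only the two ends of this small series separate. No measurement here explains why the dimethylphenyl and fluorophenyl compounds differ, so the step stands as an observation without a known cause.

As far as these compounds go, whether one methyl alone would match the 3,4-dimethylphenyl group remains open, as does the outcome with a methoxy, an amine or a carboxylic acid on the phenyl ring. Compound 1 at 33% and compound 4 at 57% share the 3-fluorophenyl group and differ at the other place on the shared core, but whether that other group matters equally with other phenyl groups is also unsettled.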